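A few compounds are considered here, and "the series" means these few. Any claim that something is new, unique, unknown or untested is made for them only; others in the source may bear on it.

Of the compounds shown here, three that share one core have been tested in a functional assay on cells for agonist activity at G-protein coupled receptor 52 (Homo sapiens), read by AlphaScreen and cAMP accumulation, with a stated time of 30 min; on this read-out lower numbers stand for an effect already at smaller amounts and higher numbers for an effect only at larger amounts of compound. Compound 1 `Cc1nc(Cc2cccc(C(F)(F)F)c2)sc1-c1ccc(C(N)=O)cc1` gives 220 nM. Compound 2 `Cc1cc(C(N)=O)ccc1-c1sc(Cc2cccc(C(F)(F)F)c2)nc1C` gives 1400 nM, so the step of a 6.4-fold higher number from compound 1 to compound 2 (0.80 log units; beyond the scatter) weakens the effect. Compound 3 `CCc1cc(-c2sc(Cc3cccc(C(F)(F)F)c3)nc2C)ccc1C(N)=O` gives 83 nM, and the step of a 2.7-fold lower number from compound 1 to compound 3 (0.42 log units; beyond the scatter) strengthens it. Among the three numbers, compound 3 therefore stands lowest, with compound 1 nearest to it and compound 2 furthest away.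

Compound 4 `Cc1nc(Cc2cccc(C(F)(F)F)c2)sc1-c1ccc(C(N)=O)c(C(F)(F)F)c1` is the next one to be tested. It differs from compound 3 by trifluoromethyl in place of ethyl on an aromatic carbon. For the measured compounds named here, two measured steps touch the same part of the core: a 6.4-fold higher number from compound 1 to compound 2 (0.80 log units; beyond the scatter) and a 2.7-fold lower number from compound 1 to compound 3 (0.42 log units; beyond the scatter). They pull in opposite directions, so a small group at this place can help or hurt, and a trifluoromethyl has not yet been tried there. Going by the values given here, with no closer precedent, the step from compound 3 to compound 4 is expected to be a 3.6-fold higher number from compound 3 to compound 4 (0.56 log units; beyond the scatter), leaning toward a weaker effect but with wide uncertainty. For compound 4 in this assay the estimate is 300 nM, with a range from 80 nM to 1500 nM.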

Compound 4, half-maximal effective concentration: 110 nM
Compound 4: the middle estimate sits 2.7-fold (0.44 log units) above what was measured, and the stated range covers the measured number.
By their numbers in this assay, from the lowest: compounds 3, 4 and 1 (each within the scatter of the next, the first and the last beyond it); then compound 2.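

In this assay, trifluoromethyl on the carbon ortho to a carbamoyl group can take the place of ethyl with a 1.3-fold higher number from compound 3 to compound 4 (0.12 log units; within the scatter) as the result, so this position accepts both groups and the assay does not tell them apart, even though the two differ in heavy atoms and one brings in fluorine. Measured against hydrogen on the same carbon, trifluoromethyl gives a 2.0-fold lower number from compound 1 to compound 4 (0.30 log units; within the scatter), whereas ethyl gives a 2.7-fold lower number from compound 1 to compound 3 (0.42 log units; beyond the scatter) and that step lies beyond the scatter. Compound 4 therefore sits within the scatter of both its neighbours, so the gain seen with ethyl cannot be said to carry over to trifluoromethyl, and equally no loss appears with it.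

Still open, from the compounds shown here alone, is how far this tolerance reaches on that carbon, for example whether a propyl chain, a methoxy group, a chlorine atom or an amine would keep the number in the same range, and the compounds here offer no experimental observation that would explain why ethyl and trifluoromethyl behave so alike.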